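A few compounds are considered here, and "the series" means these few. Any claim that something is new, unique, unknown or untested is made for them only; others in the source may bear on it.

In a functional assay on HL-60 cells (Homo sapiens) for cytotoxicity, read by MTT assay, with a stated time of 4 days (a higher number here means a weaker inhibitor, a lower number a stronger inhibitor), compound 1, with the structure `C=C1C[C@]23C[C@@]1(O)CC[C@H]2c1ccc(O)c(C)c1[C@@H]3Cn1cc(-c2ccccn2)nn1`, gives > 20000 nM, which is a limit of the assay and not a number, so where compound 1 stands rests on (the limit of > 20000 nM in this assay, at which 1 of the 2 values shown sits). Compound 2, `C=C1C[C@]23C[C@@]1(O)CC[C@H]2c1ccc(O)c(C)c1[C@@H]3Cn1cc(-c2ccc(C(F)(F)F)cc2)nn1`, gives 8950 nM in this assay. Among the measured compounds shown here, the one measured step, an at least 2.2-fold lower number from compound 1 to compound 2 (0.34 log units; beyond the scatter), alters the group on the triazole and leaves the shared core untouched. Compound 3, `C=C1C[C@]23C[C@@]1(O)CC[C@H]2c1cc(Br)c(O)c(C)c1[C@@H]3Cn1cc(-c2ccccn2)nn1`, differs from compound 1 by bromo in place of hydrogen on an aromatic carbon. For the measured compounds named here, no measured step touches that position of the core, so nothing in the data speaks to the size or direction of this change in this assay; with compound 1 reported only as a limit, the expectation is no step beyond the scatter. Compound 3 is therefore expected to give 25000 nM, with a range from 8000 nM to 80000 nM. The step this estimate means, a step that the limit leaves unreadable from compound 1 to compound 3, is an expectation only.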

Compound 3, half-maximal inhibitory concentration: > 20000 nM
Compound 3 gave a limit, no number (the forecaster's own chance of this, stated with the estimate: 60%); the middle value lies beyond the limit too.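

Compound 1 and compound 3 both stand only as limits of the assay, not as numbers, so no step can be read between them: the limit of > 20000 nM in this assay, at which 2 of the 3 values shown sit. The compounds shown leave open whether bromo in place of hydrogen on an aromatic carbon changes the number in this assay at all, and in which direction.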